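From phenyl to pyridin-2-yl on a ring amine

The source may report more compounds than this note shows. Statements on the series, on what has been measured and on what is new or still open speak of the compounds shown alone.

Compound 1 `COc1ccc(C[C@@H](O)/C=C/C=C/C(=O)NCc2ccc(Cl)cc2)cc1OC` gives 16500 nM
Compound 2 `COc1ccc(C[C@@H](O)/C=C/C=C/C(=O)N2CCN(c3ccccc3)CC2)cc1OC` gives 14200 nM
Compound 3 `COc1ccc(C[C@@H](O)/C=C/C=C/C(=O)NCc2cc(OC)c(OC)c(OC)c2)cc1OC` gives 19200 nM

In a functional assay on A549 cells (Homo sapiens) for antiproliferative activity, read by sulforhodamine B assay, with a stated time of 48 h (a higher number here means a weaker inhibitor, a lower number a stronger inhibitor), these three compounds cannot be told apart. Compound 2 at 14200 nM lies within the usual scatter of both compound 1 at 16500 nM and compound 3 at 19200 nM on the same measure. They carry different groups on the shared core, and no two of them differ in one place only, so no single change has been measured directly.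

Compound 4 `COc1ccc(C[C@@H](O)/C=C/C=C/C(=O)N2CCN(c3ccccn3)CC2)cc1OC` departs from compound 2 in one group (pyridin-2-yl in place of phenyl on an amine nitrogen in a ring) with pyridin-2-yl in place of phenyl on an amine nitrogen in a ring. Among the compounds with values here, no measured compound carries this group. Within the data shown here, the only guide is the closeness of the three values, so no step beyond the scatter is expected in this assay in either direction. The expected change is a 1.1-fold higher number from compound 2 to compound 4 (0.02 log units; within the scatter) as an estimate within the scatter. Compound 4 is estimated at 15000 nM with an expected range from 7000 nM to 30000 nM in this measure.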

Compound 4, half-maximal inhibitory concentration: 8130 nM
Beside the measured number, compound 4's estimate is 1.8-fold (0.27 log units) above it, within the range that was stated.
By their numbers in this assay, from the lowest: compounds 4, 2, 1 and 3 (each within the scatter of the next, the first and the last beyond it).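

Within the data shown here, the step from phenyl to pyridin-2-yl on an amine nitrogen in a ring is the first change in a single place to be measured in this set, and in this assay it gives a 1.7-fold lower number from compound 2 to compound 4 (0.24 log units; within the scatter). Among these compounds, at this position, then, exchanging the all-carbon aromatic ring for one with a ring nitrogen and a hydrogen-bond acceptor produces no step that can be separated from the scatter. No measurement is available that would account for this result.

The compounds shown leave open whether pyridin-3-yl or pyridin-4-yl, with the ring nitrogen placed elsewhere, would behave like pyridin-2-yl at this position. They also leave open whether a different group there, such as benzyl or a carboxylic acid, would give a step beyond the scatter in this assay.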